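The compounds below may be only part of what the source reports. "The series", "measured", "known", "first", "only" and "open" are said of these compounds alone.

Measured compounds in a toxicity assay on MT4 cells (Homo sapiens) for cytotoxicity, read by MTT assay, with a stated time of 5 days; a lower number here means that less compound is tolerated, a higher number that more compound is tolerated:

- compound 1 `Cc1ccc(C(C)C)c(OCc2nnc(SCC(=O)Nc3ccc(Br)cc3)n2Cc2ccccc2)c1` gives 66.7 ug/mL.
- compound 2 `CC(=O)Nc1ccc(OCc2nnc(SCC(=O)Nc3ccc(S(N)(=O)=O)cc3)n2Cc2ccccc2)cc1` gives only a limit of this assay, > 125 ug/mL.
- compound 3 `CC(=O)Nc1ccc(OCc2nnc(SCC(=O)Nc3ccc(Br)cc3)n2Cc2ccccc2)cc1` gives only a limit of this assay, >= 3.99 ug/mL.

Compound 3 therefore has no number of its own in this assay, only a limit, and of the three values shown a second one is also a limit. The two measured steps that lead to compound 3 are both unreadable for that reason: a step that the limit leaves unreadable from compound 1 to compound 3 and a step that the two limits leave unreadable from compound 2 to compound 3 give no size. The limits concerned are the limit of > 125 ug/mL in this assay, at which 1 of the 3 values shown sits, and (the limit of >= 3.99 ug/mL in this assay, at which 1 of the 3 values shown sits).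

Compound 4 `CCOC(=O)c1ccc(NC(=O)CSc2nnc(COc3ccc(NC(C)=O)cc3)n2Cc2ccccc2)cc1` differs from compound 3 by a single change, (ethoxycarbonyl in place of bromo on an aromatic carbon). Among the measured compounds shown here, no measured step changes this part of the structure, and the steps that do exist around compound 3 carry no readable size, so nothing here supports a step in either direction beyond the scatter. Compound 4 is expected to sit near compound 3, with the step that the limit leaves unreadable from compound 3 to compound 4 taken as small and of uncertain sign. The estimate for compound 4 in this assay is 50 ug/mL, within 10 ug/mL to 125 ug/mL, with a fair chance that only a limit is reported.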

Compound 4, half-maximal cytotoxic concentration: 91.1 ug/mL
The estimate for compound 4 lay 1.8-fold (0.26 log units) below the measured number; measured number inside the range.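

In this assay, among the compounds shown here, compound 4 gives a real number rather than a limit, 91.1 ug/mL, the first such value with the 4-acetamidophenyl group kept and the first for ethoxycarbonyl on this aromatic carbon. With ethoxycarbonyl in place of sulfamoyl, the series shows an at least 1.3-fold lower number from compound 2 to compound 4 (0.13 log units; that floor lies within the scatter), so no change beyond the scatter is established for this swap. All steps touching compound 3 remain unreadable because that compound carries only a limit: the limit of >= 3.99 ug/mL in this assay, at which 1 of the 4 values shown sits.

From the compounds shown here alone, whether bromo and ethoxycarbonyl differ at this position with the 4-acetamidophenyl group kept remains open. Also open, going by these compounds, is how a carboxylic acid or an amine on this aromatic carbon, or a longer chain on the ester oxygen in place of ethyl, would read in this assay.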